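A few compounds are considered here, and "the series" means these few. Any claim that something is new, unique, unknown or untested is made for them only; others in the source may bear on it.

Measured in a functional assay on DU-145 cells (Homo sapiens) for antiproliferative activity, read by MTT assay, with a stated time of 24 h; on this read-out higher numbers stand for weaker inhibition and lower numbers for stronger inhibition:
- compound 1 `COc1ccc(-c2noc(-c3ccncc3)n2)cc1OC1CCCC1`: > 1000000 nM
- compound 2 `COc1ccc(-c2noc(Cc3c[nH]c4ccccc34)n2)cc1OC1CCCC1`: > 1000000 nM

The reading for compound 1, > 1000000 nM, is a limit of the assay and not a number. The reading for compound 2, > 1000000 nM, is likewise a limit. Compound 1 therefore has no exact place in the series, and the only landmark so far is the limit of > 1000000 nM in this assay, at which 2 of the 2 values shown sit.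

The next compound, compound 3 `COc1ccc(-c2noc(-c3ccc(O)cc3)n2)cc1OC1CCCC1`, keeps the core of compound 1 and carries 4-hydroxyphenyl in place of pyridin-4-yl on an aromatic carbon. Going by the values given here, no two measured compounds differ in just one place, so the data do not show what a single change does in this assay. Since compound 1 gives > 1000000 nM, which is a limit, only a modest move toward stronger inhibition is expected, and the reading may well stay at the limit. The expected change is an at least 5.0-fold lower number from compound 1 to compound 3 (0.69 log units; beyond the scatter). For compound 3 the estimated value is 200000 nM, with an expected range of 20000 nM to 1000000 nM.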

Compound 3, half-maximal inhibitory concentration: 780 nM
For compound 3 the middle estimate is 260-fold (2.41 log units) above the measured one, and the stated range ends above it.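

Until now, nothing had shown that any compound in this series could give a measurable reading in this assay. Placing 4-hydroxyphenyl instead of pyridin-4-yl on the aromatic carbon of the five-membered ring changes that, with an at least 1200-fold lower number from compound 1 to compound 3 (3.10 log units; beyond the scatter), so the group at this position can decide whether the compounds register in this assay at all. The size of this step is a minimum, as the reading for compound 1 is a limit, and compound 3 is the only one of the three compounds with an exact value: the limit of > 1000000 nM in this assay, at which 2 of the 3 values shown sit.

The change does two things at once, since the ring nitrogen of pyridin-4-yl leaves and a hydroxyl group enters on an all-carbon ring, and the compounds shown cannot separate these two parts. From the compounds shown here alone, it remains open whether a plain phenyl ring would already give a measurable reading, and whether a methoxy group or an amine could take the place of the hydroxyl group.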